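This account rests on a few compounds, and the source may have more. Where it says the series, first, only, none or still open, it means among the compounds named here.

Measured compounds in an ADME assay, at pH 5; on this read-out higher numbers stand for a longer-lived compound and lower numbers for a shorter-lived compound:
compound 1 `COc1cnc(C[S+]([O-])c2nc3cc(OC(F)F)ccc3[nH]2)c(C)c1OC` gives 3.7 h
compound 2 `COc1ccnc(C[S+]([O-])c2nc3cc(OC(F)F)ccc3[nH]2)c1C` gives 0.17 h
compound 3 `COc1cnc(C[S+]([O-])c2nc3cc(OC(F)(F)C(F)F)ccc3[nH]2)cc1OC` gives 2.9 h

Compound 4 `COc1ccnc(C[S+]([O-])c2nc3cc(OC(F)(F)C(F)F)ccc3[nH]2)c1` has not yet been measured in this assay. Compound 3 and compound 4 differ by hydrogen in place of methoxy on an aromatic carbon. The same kind of change separates compound 1 from compound 2, (hydrogen in place of methoxy on an aromatic carbon), the surroundings differing in that the place in compound 1 is also meta to a methyl group. That step gave a 22-fold lower number from compound 1 to compound 2 (1.34 log units; beyond the scatter). How the core of compound 1 differs from the core of compound 3 is not broken down here; in this assay compound 1 and compound 3 give values within the usual scatter of each other.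

For the measured compounds named here, for compound 4 a step of a 19-fold lower number from compound 3 to compound 4 (1.29 log units; beyond the scatter) is expected, resting on the single earlier step of a 22-fold lower number from compound 1 to compound 2 (1.34 log units; beyond the scatter) with the same kind of change. Compound 4 is therefore estimated at 0.15 h, with a likely range from 0.05 h to 0.5 h.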

Compound 4, half-life: 0.8 h
Compound 4: the middle estimate sits 5.3-fold (0.73 log units) below what was measured; measured number above the stated range.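

In this assay, hydrogen in place of methoxy lowers the number on both cores, but the size of the drop does not carry over, the new step being a 3.6-fold lower number from compound 3 to compound 4 (0.56 log units; beyond the scatter), and the two steps stand clearly apart: the same change on two cores in this assay, a 22-fold lower number (1.34 log units; beyond the scatter) from compound 1 to compound 2 and a 3.6-fold lower number (0.56 log units; beyond the scatter) from compound 3 to compound 4, 6.0-fold (0.78 log units) apart, beyond the scatter of two such steps. For this change, the earlier step is therefore a guide to direction across these two pairs, not to size. For the compounds shown here, with only two pairs, and the differences between the two cores not broken down, the data do not show which part of the core sets the size of the step.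

Still open, from the compounds shown here alone, is how an ethoxy group or an amine would read in place of the methoxy group. A third core carrying the same change would show whether either step size recurs.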